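The compounds below may be only part of what the source reports. "The series", "measured", "known", "first", "only" and "open" are said of these compounds alone.

The compounds measured so far, with their values:

Compound 1, `CS(=O)(=O)c1ccc(N2N=C(c3ccccc3)CCC2=O)cc1`, gives 47.3% in a functional assay on the whole organism (strain Wistar) for inhibition, with Rattus norvegicus as the target, read by paw edema, with stated times of 30 min and 5 h, at a dose of 0.05 mmol/kg by the oral route; a higher number here means more inhibition at the dose given (going by the name of the read-out), a lower number less inhibition.
Compound 2, `Cc1cc(O)ccc1C1=NN(c2ccc(S(C)(=O)=O)cc2)C(=O)CC1`, gives 52.6% in this assay.
Compound 3, `CS(=O)(=O)c1ccc(N2N=C(c3ccc(Br)cc3)CCC2=O)cc1`, gives 31.5% in this assay.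

Compound 3 stands lowest of the three numbers. Its nearest neighbour is compound 1, and the change a number 15.8 percentage points lower from compound 1 to compound 3 (beyond the scatter) lies beyond the scatter; the gap to compound 2 is wider still, as a number 21.1 percentage points lower from compound 2 to compound 3 (beyond the scatter) shows. Between compound 1 and compound 2 the change a number 5.3 percentage points higher from compound 1 to compound 2 (within the scatter) stays within the scatter.

The step to compound 4, `CS(=O)(=O)c1ccc(N2N=C(c3ccc(O)c(Cl)c3)CCC2=O)cc1`, makes one change: 3-chloro-4-hydroxyphenyl in place of 4-bromophenyl on a carbon with a double bond to nitrogen. For the measured compounds named here, two measured steps bear on this. Going from compound 2 to compound 3 removed the hydroxyl-bearing ring and brought in the bromo-bearing ring, and a number 21.1 percentage points lower from compound 2 to compound 3 (beyond the scatter) was a modest loss. Going from compound 1 to compound 3 added only bromo and a number 15.8 percentage points lower from compound 1 to compound 3 (beyond the scatter) was also a modest loss. Going by the values given here, compound 4 returns a hydroxyl to the ring and exchanges the bromo for a chloro placed next to it; no compound shows that arrangement, so its effect is uncertain.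

The expected step for compound 4 in this assay is therefore a number 14.5 percentage points higher from compound 3 to compound 4 (beyond the scatter), upward and beyond the scatter. Compound 4 is estimated at 46%, with a range from 32% to 60%.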

Compound 4, a percentage reported as inhibition, in the whole organism at one dose (the size of the read-out at that dose, not a potency): 55.2%
Estimate against measurement, compound 4: 9.2 percentage points below; the range from low to high includes it.
By their numbers in this assay, from the lowest: compound 3; then compounds 1, 2 and 4 (each within the scatter of the next).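

In this assay, putting 3-chloro-4-hydroxyphenyl in place of 4-bromophenyl at this position, on the carbon with a double bond to nitrogen, wins back what the bromo ring lost (a number 23.7 percentage points higher from compound 3 to compound 4 (beyond the scatter)). The new ring cannot be told apart from the other two rings, as the steps against plain phenyl (a number 7.9 percentage points higher from compound 1 to compound 4 (within the scatter)) and against 4-hydroxy-2-methylphenyl (a number 2.6 percentage points higher from compound 2 to compound 4 (within the scatter)) show. A halogen on this ring therefore does not by itself go with the low number, and among these four compounds only compound 3, the one with 4-bromophenyl, stands apart from the rest.

As far as these compounds go, this step swaps the whole ring, so the separate shares of the hydroxyl and the chloro stay open, as does the question of whether a ring carrying an amine or a carboxylic acid would hold this level of inhibition. Nothing measured here explains why these rings differ.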